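The source may report more compounds than this note shows. Statements on the series, on what has been measured and on what is new or still open speak of the compounds shown alone.

Compound 1 `O=C(c1ccncc1)N1N=C(c2cc3ccccc3o2)CC1c1ccccc1O` in an ADME assay on Vero cells (Chlorocebus sabaeus) for cytotoxicity, read by MTT assay, with a stated time of 72 h (on this read-out higher numbers stand for weaker inhibition and lower numbers for stronger inhibition), gives > 195000 nM, a limit of the assay rather than a number.
Compound 2 `CN(C)c1ccc(C2CC(c3cc4ccccc4o3)=NN2C(=O)c2ccncc2)cc1` in this assay gives > 210000 nM, again a limit.
Compound 3 `O=C(c1ccncc1)N1N=C(c2cc3ccccc3o2)CC1c1ccco1` in this assay gives > 208000 nM, also a limit.

Compound 3 therefore stands only at a limit, and the two other values shown are limits as well, so no order among the three can be read (the limit of > 195000 nM in this assay, at which 1 of the 3 values shown sits, (the limit of > 208000 nM in this assay, at which 1 of the 3 values shown sits), (the limit of > 210000 nM in this assay, at which 1 of the 3 values shown sits)). The change now followed is 2-phenylethenyl in place of furan-2-yl on a saturated ring carbon, giving compound 4 `O=C(c1ccncc1)N1N=C(c2cc3ccccc3o2)CC1/C=C/c1ccccc1`. The measured steps that touch the same saturated ring carbon are a step that the two limits leave unreadable from compound 1 to compound 3, a step that the two limits leave unreadable from compound 2 to compound 3 and a step that the two limits leave unreadable from compound 1 to compound 2; each has two limits at its ends, so none has a readable size, and none shows a cytotoxic effect within the tested range. For compound 4 the expected step is a step that the limit leaves unreadable from compound 3 to compound 4, most likely again ending at a limit. Compound 4 is therefore estimated at 300000 nM, with a range from 100000 nM to 1000000 nM.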

Compound 4, half-maximal inhibitory concentration: > 212000 nM
Compound 4: only a limit was reported; the forecaster's own chance of this, stated with the estimate: 85%; the middle value is on the limit's open side.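

Compound 4 ends at a limit in this assay, as do compound 1, compound 2 and compound 3, and none of the steps from those three compounds to compound 4 can be read. The compounds shown leave open how these four differ in cytotoxicity, and at what concentration any of them would produce half-maximal inhibition.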